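Adding an amino group to compound 2

A few compounds are considered here, and "the series" means these few. Any claim that something is new, unique, unknown or untested is made for them only; others in the source may bear on it.

In an ADME assay on Vero cells (Chlorocebus sabaeus) for cytotoxicity, with a stated time of 5 days (on this read-out higher numbers stand for weaker inhibition and lower numbers for stronger inhibition), compound 1 `CC(C)(CO)Nc1nc(N)nc2c1ncn2[C@H]1C[C@H](N=[N+]=[N-])[C@@H](CO)O1` gives > 100000 nM as a limit of the assay, not a number. Compound 2 `C=CCNc1ncnc2c1ncn2[C@H]1C[C@H](N=[N+]=[N-])[C@@H](CO)O1` gives > 100000 nM as a limit too. Compound 2 therefore has no number of its own and stands with compound 1 at the limit of > 100000 nM in this assay, at which 2 of the 2 values shown sit, in the data so far. Compound 3 `C=CCNc1nc(N)nc2c1ncn2[C@H]1C[C@H](N=[N+]=[N-])[C@@H](CO)O1` differs from compound 2 by a single change amino in place of hydrogen on an aromatic carbon in which amino replaces hydrogen on an aromatic carbon, between two ring nitrogen atoms. Compound 1 also carries an amino group in that place and still gives > 100000 nM as its limit. No change beyond the scatter is therefore expected in this assay and no direction can be favoured, so the estimated a number no higher from compound 2 to compound 3 (the limit leaves the size open) is small. Compound 3 is expected to read 100000 nM in this assay with an estimated range of 40000 nM to 200000 nM and may well return only a limit.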

Compound 3, half-maximal inhibitory concentration: > 100000 nM
Compound 3 was reported as a limit; the forecaster's own chance of this, stated with the estimate: 75%; the middle value sits exactly at the limit.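

In this assay compound 3 joins compound 1 and compound 2 at a limit of the assay, so no step from either compound to compound 3 can be read: the limit of > 100000 nM in this assay, at which 3 of the 3 values shown sit.

From the compounds shown here alone, the true values of all three compounds remain open, as does whether the amino or allyl change alters this read-out at all.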